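Removing the Oxymethylene Spacer and Adding a Ring Methyl

A few compounds are considered here, and "the series" means these few. Any claim that something is new, unique, unknown or untested is made for them only; others in the source may bear on it.

Compound 1 `Cc1c(OCCCCOCOc2ccc(C(=O)O)cc2)ccc(C(=O)CC2CCCC2)c1O` — 228 nM
Compound 2 `Cc1c(OCCCCOc2cccc(C(=O)O)c2)ccc(C(=O)CC(C)C)c1C` — "not active" (no number reported)
Compound 3 `CCCC(=O)c1ccc(OCCCCOc2ccc(C(=O)O)cc2C)c(C)c1O` — 104 nM

In an assay on HEK293 cells for positive allosteric modulation of metabotropic glutamate receptor 2 (Rattus norvegicus), read by thallium flux, with a stated time of 2.5 min (a lower number here means that less compound is needed, a higher number that more compound is needed for the effect), compound 1 gives 228 nM, the higher of the two numbers reported; compound 3 comes out lower, and compound 2 shows no activity. Compound 4 `Cc1ccc(C(=O)O)cc1OCCCCOc1ccc(C(=O)CC2CCCC2)c(O)c1C` has not yet been measured. It differs from compound 1 in one place: 5-carboxy-2-methylphenyl in place of (4-carboxyphenoxy)methyl on an oxygen on a saturated carbon. Compound 4 thus carries the aryl end of compound 3 while keeping the acyl end of compound 1. Because compound 3 gives 104 nM, compound 4 is expected to land near that value, so the step of a 2.1-fold lower number from compound 1 to compound 4 (0.32 log units; beyond the scatter) is estimated to be a modest drop, to about 110 nM, within 45 nM to 280 nM.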

Compound 4, half-maximal effective concentration: 1290 nM
The estimate for compound 4 lay 12-fold (1.07 log units) below the measured number, and the stated range ends below it.
By their numbers in this assay, from the lowest: compound 3; then compound 1; then compound 4.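

In this assay, placing 5-carboxy-2-methylphenyl in place of (4-carboxyphenoxy)methyl on an oxygen on a saturated carbon gives a 5.7-fold higher number from compound 1 to compound 4 (0.75 log units; beyond the scatter). This position is therefore sensitive to the group it carries, and a carboxy-bearing aromatic ring at this place does not by itself keep the number low. Nothing in the data given accounts for this step.

The compounds shown do not separate the loss of the oxymethylene spacer from the gain of the ring methyl. On these data alone, whether an amide or a tetrazole could stand in for the carboxylic acid at this end also remains open.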